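The source may report more compounds than this note shows. Statements on the series, on what has been measured and on what is new or still open speak of the compounds shown alone.

In a toxicity assay on Vero cells (Chlorocebus sabaeus) for cytotoxicity, read by MTT assay, with a stated time of 72 h (a higher number here means a weaker inhibitor, a lower number a stronger inhibitor), compound 1 (`O=C(c1cccc2ccccc12)n1c(C2CCC2)nc2ccccc21`) gives > 10000 nM as a limit of the assay and not a number. Compound 2 (`COc1ccc(C(=O)n2c(C(C)C)nc3ccccc32)cc1`) gives > 10000 nM as a limit too, so its position is only the limit of > 10000 nM in this assay, at which 2 of the 2 values shown sit, for now. Compound 3 (`COc1ccc(C(=O)n2c(-c3ccc(OC)cc3)nc3ccccc32)cc1`) has 4-methoxyphenyl in place of isopropyl on an aromatic carbon with the rest of compound 2 unchanged. No measured step sizes this change, and in this assay no step beyond the scatter is expected. The estimated step is a step that the limit leaves unreadable from compound 2 to compound 3 on that reading. For compound 3 the expected value is 20000 nM within an estimated range from 6000 nM to 60000 nM and the assay will most likely report only a limit again.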

Compound 3, half-maximal inhibitory concentration: > 10000 nM
Compound 3: a limit, no number (the forecaster's own chance of this, stated with the estimate: 75%); the middle value is on the limit's open side.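

No step can be read between compound 2 and compound 3, as each stands only as a limit of this assay and not a number. The compounds shown leave open where any true half-maximal value lies, with all of them resting at one limit: the limit of > 10000 nM in this assay, at which 3 of the 3 values shown sit.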